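Methoxy in place of piperidin-1-yl: series notes

A few compounds are considered here, and "the series" means these few. Any claim that something is new, unique, unknown or untested is made for them only; others in the source may bear on it.

Values in an ADME assay on GM00637 cells (Homo sapiens) for cytotoxicity, read by MTT assay, with a stated time of 72 h; a higher number here means a weaker inhibitor, a lower number a stronger inhibitor:
- compound 1 `CNc1cc2nc(-c3ccccc3)nn(-c3ccccc3)c-2cc1=O`: 930 nM
- compound 2 `O=c1cc2n(-c3ccccc3)nc(-c3ccccc3)nc-2cc1N1CCCC1`: 1790 nM
- compound 3 `O=c1cc2n(-c3ccccc3)nc(-c3ccccc3)nc-2cc1N1CCCCC1`: 1190 nM

Compound 3, at 1190 nM, cannot be separated from the other two compounds. Its nearest neighbour is compound 1, with a 1.3-fold higher number from compound 1 to compound 3 (0.11 log units; within the scatter). Its furthest is compound 2, with a 1.5-fold lower number from compound 2 to compound 3 (0.18 log units; within the scatter). The remaining pair gives a 1.9-fold higher number from compound 1 to compound 2 (0.28 log units; within the scatter). So methylamino, pyrrolidin-1-yl and piperidin-1-yl have so far made no difference beyond the scatter in this assay.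

The next compound is compound 4 `COc1cc2nc(-c3ccccc3)nn(-c3ccccc3)c-2cc1=O`, which has methoxy in place of piperidin-1-yl on an aromatic carbon. Among the measured compounds shown here, these three steps are the only evidence that bears on this change, and all of them are small. For the measured compounds named here, none of the measured compounds carries methoxy, so the evidence is indirect and the range has to stay wide. No step beyond the scatter is expected, and no direction can be favoured. The expected change is a 1.0-fold lower number from compound 3 to compound 4 (0.01 log units; within the scatter). For compound 4 the estimated value is 1150 nM, with an expected range of 480 nM to 2800 nM.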

Compound 4, half-maximal inhibitory concentration: > 5000 nM
Compound 4 ended at the assay's limit; the forecaster's own chance of this, stated with the estimate: 2%; middle value at least 4.3-fold (0.63 log units) away from the limit.
By their numbers in this assay, from the lowest: compounds 1, 3 and 2 (each within the scatter of the next). At a limit, above all of these: compound 4.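

Compound 4 gives no number in this assay, only a limit of the assay: the limit of > 5000 nM in this assay, at which 1 of the 4 values shown sits.

The position on this aromatic carbon is therefore not indifferent to its substituent: methylamino, pyrrolidin-1-yl and piperidin-1-yl could not be separated from one another, whereas methoxy gives an at least 4.2-fold higher number from compound 3 to compound 4 (0.62 log units; beyond the scatter), an at least 2.7-fold higher number from compound 2 to compound 4 (0.44 log units; beyond the scatter) and an at least 5.3-fold higher number from compound 1 to compound 4 (0.73 log units; beyond the scatter). Piperidin-1-yl and methoxy carry the same counts of hydrogen-bond donors and acceptors, so those counts do not account for the step from compound 3, and what differs between the two groups is the heavy-atom count, the ring and the atom attached to the aromatic carbon.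

As far as these compounds go, how far compound 4 lies beyond its limit stays unknown, so the true size of all three steps is open, and the contrast between the three nitrogen-linked groups and an oxygen-linked group rests on this one compound. An ethoxy group or a hydroxyl group at this carbon would show whether the result extends beyond methoxy, and dimethylamino or morpholin-4-yl would test how far the nitrogen-linked groups stay together.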